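The compounds below may be only part of what the source reports. "The series", "measured", "known", "first", "only" and "open" are said of these compounds alone.

In a functional assay on PC-3 cells (Homo sapiens) for inhibition, with a stated time of 72 h (on this read-out higher numbers stand for weaker inhibition and lower numbers for stronger inhibition), compound 1 `Cc1nc(-c2nc[nH]n2)ccc1-c1cnc2c(n1)N([C@H]1CC[C@@H](O)CC1)C(=O)CN2` gives 37 nM, compound 2 `CO[C@H]1CC[C@@H](CN2C(=O)CNc3ncc(-c4ccc(-c5nc[nH]n5)nc4C)nc32)CC1` gives 24 nM and compound 3 `Cc1nc(-c2nc[nH]n2)ccc1-c1cnc2c(n1)N(C(C)C)C(=O)CN2` gives 149 nM. Compound 3 therefore has the highest number of the three and is the weakest, with both of its steps beyond the scatter.

The next change leads to compound 4 `Cc1nc(-c2nc[nH]n2)ccc1-c1cnc2c(n1)N([C@H]1CC[C@H](O)CC1)C(=O)CN2`, with 4-hydroxycyclohexyl in place of isopropyl on an amide-type nitrogen in a ring. Compound 4 carries the same named group as compound 1 but differs in the arrangement at its defined stereocentres.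

The closest evidence is a 4.0-fold higher number from compound 1 to compound 3 (0.60 log units; beyond the scatter), which is the same exchange of groups read in reverse. The step of a 6.2-fold higher number from compound 2 to compound 3 (0.79 log units; beyond the scatter) also leaves compound 3 with the higher number, while a 1.5-fold lower number from compound 1 to compound 2 (0.19 log units; within the scatter) lies within the scatter. Going by the values given here, no measured pair shows what the stereocentre arrangement alone does in this assay, so a somewhat smaller drop than the one seen with compound 1 is expected, though still beyond the scatter.

For compound 4 the expected change is a 3.0-fold lower number from compound 3 to compound 4 (0.47 log units; beyond the scatter). The estimate for compound 4 is 50 nM, with an expected range of 18 nM to 130 nM.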

Compound 4, half-maximal inhibitory concentration: 119 nM
Compound 4: middle estimate off by 2.4-fold (0.38 log units), on the low side; the measured number falls inside the stated range.
By their numbers in this assay, from the lowest: compounds 2 and 1 (each within the scatter of the next); then compounds 4 and 3 (each within the scatter of the next).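

At this position, the amide-type nitrogen in a ring, the drawn configuration of the 4-hydroxycyclohexyl group counts in this assay, with a 3.2-fold higher number from compound 1 to compound 4 (0.51 log units; beyond the scatter), and this step can be traced to one difference alone, because of this: the fact that compounds 1 and 4 differ only in the configuration as drawn

The 4-hydroxycyclohexyl group alone therefore does not secure the lower number of compound 1: in the configuration of compound 4, its exchange for isopropyl gives a 1.3-fold lower number from compound 3 to compound 4 (0.10 log units; within the scatter), which lies within the scatter. Read against this same isomer, the (4-methoxycyclohexyl)methyl group of compound 2 remains clearly separated, with a 5.0-fold higher number from compound 2 to compound 4 (0.70 log units; beyond the scatter), so the two cyclohexyl-bearing groups cannot be treated as alike without regard to how they are drawn.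

Still open, on these data alone, is whether the drawn configuration counts as much for (4-methoxycyclohexyl)methyl as it does for 4-hydroxycyclohexyl. Also open, as far as these compounds go, is how a plain cyclohexyl, or an amine or a carboxylic acid in place of the hydroxy group on that ring, would read in this assay in each configuration.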